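A few compounds are considered here, and "the series" means these few. Any claim that something is new, unique, unknown or untested is made for them only; others in the source may bear on it.

Measured so far in a functional assay on HEK293 cells for agonist activity at lutropin-choriogonadotropic hormone receptor (Homo sapiens), read by cAMP accumulation; on this read-out lower numbers stand for smaller maximal responses and higher numbers for larger maximal responses:
Compound 1 `CSc1nc(-c2cccc(O)c2)c2c(N)c(C(=O)NC(C)(C)C)sc2n1` gives 63.9%.
Compound 2 `COc1cccc(-c2nc(SC)nc3sc(C(=O)N(C)C(C)(C)C)c(N)c23)c1` gives 47.8%.
Compound 3 `CSc1nc(-c2cccc(F)c2)c2c(N)c(C(=O)NC(C)(C)C)sc2n1` gives 51.1%.

Compound 2 has the lowest of the three numbers. Its value and that of compound 3 lie within the scatter of each other, so no order between those two can be claimed; compound 1 sits beyond the scatter above compound 2. Among the measured compounds shown here, the only step between two compounds that differ in one place is a number 12.8 percentage points lower from compound 1 to compound 3 (beyond the scatter), a modest drop.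

Compound 4 `COc1cccc(-c2nc(SC)nc3sc(C(=O)NCCO)c(N)c23)c1` is the compound still to be measured. It differs from compound 2 at the carbonyl carbon: (2-hydroxyethyl)amino in place of methyl(tert-butyl)amino on a carbonyl carbon. For the measured compounds named here, no measured step touches this part of the molecule. Going by the values given here, the one step known, from compound 1 to compound 3, changes a group on an aromatic carbon, so it says nothing directly about swapping the group on the carbonyl carbon. With nothing closer to lean on, the expectation for compound 4 is a step of no clear direction, most likely within the scatter: a number 2.2 percentage points higher from compound 2 to compound 4 (within the scatter). Compound 4 is therefore estimated at 50%, within the range 33% to 67%.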

Compound 4, largest response reached (reported as efficacy), in percent of the reference or control that the assay uses: 20.5%
Compound 4: middle estimate off by 29.5 percentage points, on the high side; the whole stated range lies above it.
By their numbers in this assay, from the lowest: compound 4; then compounds 2 and 3 (each within the scatter of the next); then compound 1.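

The carbonyl carbon had not been touched by any earlier step, and this result shows that the group placed there matters in this assay: (2-hydroxyethyl)amino in place of methyl(tert-butyl)amino gives a number 27.3 percentage points lower from compound 2 to compound 4 (beyond the scatter) and the change lies clearly beyond the usual scatter. The swap alters several things at once, including the heavy-atom count of the group, its hydrogen-bond donors and acceptors, and the presence of the hydroxy group, so this single step cannot show which of these goes with the lower maximal response. Nothing among the available measurements offers an explanation for the drop.

The compounds shown leave open whether the lower number follows the loss of the branched methyl(tert-butyl)amino group or the arrival of the hydroxy group at the end of the new chain. A plain ethylamino group, a 2-methoxyethylamino group or a longer 3-hydroxypropylamino chain on the same carbonyl carbon would each separate these possibilities, and the same holds for a small ring amine such as morpholine.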